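The source may report more compounds than this note shows. Statements on the series, on what has been measured and on what is new or still open speak of the compounds shown alone.

Working notes on the series. Among the compounds with values here, in a functional assay on SF-539 cells (Homo sapiens) for inhibition, read by sulforhodamine B assay, with a stated time of 48 h (a lower number here means a stronger inhibitor of growth, a higher number a weaker inhibitor of growth), compound 3 `COc1cc(C(=O)N2CCN(C=O)C2=S)cc(OC)c1OC` gives 21300 nM; this is the only number in hand. Compound 1 `N#C/C(=C\N1CCN(C(=O)c2ccco2)C1=S)C(=O)Nc1ccc(Cl)cc1` gives "not determined" (no result reported) in this assay, and compound 2 `N#C/C(=C\N1CCN(C(=O)c2ccco2)C1=S)C(N)=O` gives "not determined" (no result reported), so compound 2 stands nowhere on the numbers shown: it has no value, and the one further compound of its kind is equally without a value. The step to compound 4 `N#C/C(=C\N1CCN(C(=O)c2ccco2)C1=S)C(=O)c1ccccc1` is phenyl in place of amino on a carbonyl carbon, read one bond further out as carbamoyl to benzoyl. Within the data shown here, no step between measured compounds exists here, so the size and direction of this change in this assay cannot be set against any precedent; the only anchor is compound 3. On that basis compound 4 is expected to give about 15000 nM, with a range from 3000 nM to 60000 nM.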

Compound 4, concentration for 50% growth inhibition: 2200 nM
Estimate against measurement, compound 4: 6.8-fold (0.83 log units) above; the whole stated range lies above it.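

No step can be read from compound 4 in this assay: its partner, compound 2, has no single number. The compounds shown leave open what carbamoyl to benzoyl does to growth inhibition. No evidence bears on this result.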